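The source may report more compounds than this note shows. Statements on the series, on what has been measured and on what is new or still open speak of the compounds shown alone.

Compound 1 `CC1(C)[C@H]2CC[C@]1(C)N(Cc1cn(-c3ccccc3O)nn1)C(=O)C2` was tested in a functional assay on OVCAR-3 cells (Homo sapiens) for inhibition, read by MTT assay, with a stated time of 24 h (on this read-out higher numbers stand for weaker inhibition and lower numbers for stronger inhibition), where compound 1 gives 90 nM. Among the three measured compounds, compound 1 stands second highest: compound 2 `CC1(C)[C@H]2CC[C@]1(C)N(Cc1cn(-c3ccc(F)cc3)nn1)C(=O)C2` gives 200 nM in this assay, and compound 3 `CC1(C)[C@H]2CC[C@]1(C)N(Cc1cn(-c3ccccc3Cl)nn1)C(=O)C2` gives 40 nM. The steps between them are modest: a 2.2-fold higher number from compound 1 to compound 2 (0.35 log units; beyond the scatter), a 2.3-fold lower number from compound 1 to compound 3 (0.35 log units; beyond the scatter) and a 5.0-fold lower number from compound 2 to compound 3 (0.70 log units; beyond the scatter).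

Compound 4 `Cc1cccc(-n2cc(CN3C(=O)C[C@@H]4CC[C@@]3(C)C4(C)C)nn2)c1` has not yet been measured. It differs from compound 1 in one place: 3-methylphenyl in place of 2-hydroxyphenyl on an aromatic nitrogen

Going by the values given here, none of the measured steps makes this exact change. The nearest points of comparison are the step from compound 1 to compound 3, where chloro in place of hydroxy on the aromatic carbon gave a lower number, and the step from compound 1 to compound 2, where 4-fluorophenyl in place of 2-hydroxyphenyl gave a higher number. These two steps point in opposite directions and are each of a similar size, so for 3-methylphenyl in place of 2-hydroxyphenyl no step beyond the scatter in this assay is firmly expected in either direction.

The step from compound 1 to compound 4 is therefore estimated as a 1.1-fold higher number from compound 1 to compound 4 (0.05 log units; within the scatter). In this assay, compound 4 is expected to give about 100 nM, with a likely range from 40 nM to 250 nM.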

Compound 4, half-maximal inhibitory concentration: 160 nM
Beside the measured number, compound 4's estimate is 1.6-fold (0.20 log units) below it; the measured number falls inside the stated range.
By their numbers in this assay, from the lowest: compound 3; then compounds 1, 4 and 2 (each within the scatter of the next, the first and the last beyond it).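

In this assay, 3-methylphenyl, with no hydrogen-bond donor or acceptor, stays within the scatter of 2-hydroxyphenyl on the aromatic nitrogen of the triazole-type ring (the step is a 1.8-fold higher number from compound 1 to compound 4 (0.25 log units; within the scatter)), so on these compounds the hydroxy group is not needed to keep a number of this size. The step to 4-fluorophenyl is also within the scatter (it is a 1.3-fold lower number from compound 2 to compound 4 (0.10 log units; within the scatter)), which means compound 4 cannot be told apart from either compound 1 or compound 2, although those two are separated beyond the scatter. Only 2-chlorophenyl stands clearly apart from the new compound (the step is a 4.0-fold higher number from compound 3 to compound 4 (0.60 log units; beyond the scatter)), and this step changes both the group and where it sits on the phenyl ring, so it cannot assign the difference to either one alone.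

The compounds shown leave open whether the lower number of compound 3 follows the chloro group or its place, which a 3-chlorophenyl or a 2-methylphenyl compound would separate, and how a 2-aminophenyl group would fare at this position. Nothing given here bears on why these numbers differ.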